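This account rests on a few compounds, and the source may have more. Where it says the series, first, only, none or still open, it means among the compounds named here.

Working notes on the series. In a functional assay on SF-268 cells (Homo sapiens) for cytotoxicity, read by sulforhodamine B assay, with a stated time of 48 h (a lower number here means that less compound is tolerated, a higher number that more compound is tolerated), compound 2 `ClCc1ccc(Cn2cnc3nc(Cl)nc(Cl)c32)cc1` gives 7940 nM. Compound 1 `ClCc1ccc(Cn2cnc3c(Cl)ncnc32)cc1` gives 9330 nM in this assay. For compound 3 `ClCc1ccccc1Cn1cnc2nc(Cl)nc(Cl)c21` this assay returns only a limit, > 100000 nM; that is the ceiling described by the limit of > 100000 nM in this assay, at which 1 of the 3 values shown sits. Of the two numbers shown, compound 2 carries the lower one, but compound 1 is nearest and within the scatter of it, so the two cannot be ranked. Compound 4 `ClCc1ccc(Cn2cnc3ncnc(Cl)c32)cc1` is next; relative to compound 2 the change is hydrogen in place of chloro on an aromatic carbon. For the measured compounds named here, no single-change step among the measured compounds is available to size such a change, so in this assay no step beyond the scatter is expected in either direction. Compound 4 is estimated at 10000 nM, with a range from 4000 nM to 30000 nM. The step of a 1.3-fold higher number from compound 2 to compound 4 (0.10 log units; within the scatter) is expected to stay within the scatter.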

Compound 4, concentration lethal to 50% of the cells: 7070 nM
Compound 4: the middle estimate sits 1.4-fold (0.15 log units) above what was measured; low and high end bracket the measured number.
By their numbers in this assay, from the lowest: compounds 4, 2 and 1 (each within the scatter of the next). At a limit, above all of these: compound 3.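

In this assay, for the compounds shown here, the first single-change step sizes the chloro group between two ring nitrogen atoms: hydrogen in its place gives a 1.1-fold lower number from compound 2 to compound 4 (0.05 log units; within the scatter). At this position, then, removing the chloro group leaves the concentration lethal to half of the cells unresolved from that of the parent compound. Nothing measured bears on a cause for this step. Still open, going by these compounds, is whether another group at this position, such as an amine, a methoxy group or a longer chain, would give a step beyond the scatter. Also open, on these data alone, is what a hydroxymethyl group in place of the chloromethyl group would do.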